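The source may report more compounds than this note shows. Statements on the series, on what has been measured and on what is new or still open speak of the compounds shown alone.

Compound 1 `C=CC1=C(C(=O)NCCCCC)C(c2ccc(OC)cc2)OC1` gives > 100000 nM in a functional assay on QGY7701 cells (Homo sapiens) for cytotoxicity, read by MTT assay, with a stated time of 24 h (on this read-out higher numbers stand for weaker inhibition and lower numbers for stronger inhibition), a limit of the assay rather than a number.
Compound 2 `C=CC1=C(C(=O)NCCC)C(c2ccc(OC)c(OC)c2)OC1` gives > 100000 nM in this assay, again a limit.
Compound 3 `C=CC1=C(C(=O)NCCCCC)C(c2ccc(F)cc2)OC1` gives > 100000 nM in this assay, again a limit.

None of the three measured compounds therefore has a read number in this assay; compound 3 stands, like the other two, at the limit, and its placing relative to compound 1 and compound 2 cannot be read. Among the measured compounds shown here, the one single-point step among them, a step that the two limits leave unreadable from compound 1 to compound 3, is unreadable for the same reason, since both of its ends are limits. That is the whole of the evidence: the limit of > 100000 nM in this assay, at which 3 of the 3 values shown sit.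

Compound 4 `C=CC1=C(C(=O)NCc2ccccc2)C(c2ccc(F)cc2)OC1` is the next compound on this path. It differs from compound 3 in one place, (phenyl in place of butyl on a saturated chain carbon bound to an amide-type nitrogen), so the pentylamino side of compound 3 becomes benzylamino in compound 4. For the measured compounds named here, no measured step bears on this change; the only measured step, from compound 1 to compound 3, is unreadable in size, so no direction can be taken from it. With every measured neighbour at the limit, the expectation is that compound 4 will also sit at or near that limit in this assay, and the step that the limit leaves unreadable from compound 3 to compound 4 is estimated to be no more than the scatter. Compound 4 is therefore expected to give about 150000 nM in this assay, within 40000 nM to 600000 nM, most likely reported only as a limit.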

Compound 4, half-maximal inhibitory concentration: 67600 nM
Beside the measured number, compound 4's estimate is 2.2-fold (0.35 log units) above it, within the range that was stated.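

Compound 4 is the first compound shown to give a read number in this assay, which places the side on the amide nitrogen as the one point of the series where a change has so far been accompanied by a value rather than a limit. Benzylamino in place of pentylamino gives an at least 1.4-fold lower number from compound 3 to compound 4 (0.17 log units; that floor lies within the scatter); compound 3 is a limit, so this figure is only a floor, and the true size of the step cannot be read, nor can it be said to exceed the usual scatter of this assay. The evidence therefore gives a first number but not yet a firm trend, with the other compounds still sitting at a single ceiling: the limit of > 100000 nM in this assay, at which 3 of the 4 values shown sit.

It remains open whether the number of compound 4 depends on the fluoro group, since benzylamino is shown only alongside fluoro and not alongside methoxy on the aromatic ring. The compounds shown also leave unsettled how a phenethyl chain, a cyclohexylmethyl group or a pyridylmethyl group on the same nitrogen would compare with benzyl.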